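Chain extension from compound 3 to compound 4

This account rests on a few compounds, and the source may have more. Where it says the series, first, only, none or still open, it means among the compounds named here.

Values in a functional assay on RAW264.7 cells (Mus musculus) for inhibition, read by ELISA, with a stated time of 24 h (a higher number here means that more compound is needed for the effect, a lower number that less compound is needed), so far
- compound 1 `CC/C=C\C[C@H]1C(=O)C=C[C@H]1CC(=O)OCCCC` gives 23000 nM
- compound 2 `CC/C=C\C[C@H]1C(=O)C=C[C@H]1CC(=O)OCCCCC` gives 25000 nM
- compound 3 `CC/C=C\C[C@H]1C(=O)C=C[C@H]1CC(=O)OCCO` gives 24000 nM

Compound 3 at 24000 nM stands within the scatter of both other compounds. Compound 4 `CC/C=C\C[C@H]1C(=O)C=C[C@H]1CC(=O)OCCOCCO` differs from it by one change (2-hydroxyethyl in place of hydrogen on an oxygen on a saturated carbon), with 2-hydroxyethyl in place of hydrogen on an oxygen on a saturated carbon. Three measured chain changes bear on it: methyl in place of hydrogen (a 1.1-fold higher number from compound 1 to compound 2 (0.04 log units; within the scatter)), hydroxy in place of ethyl (a 1.0-fold higher number from compound 1 to compound 3 (0.02 log units; within the scatter)) and hydroxy in place of propyl (a 1.0-fold lower number from compound 2 to compound 3 (0.02 log units; within the scatter)). All lie within the scatter, though none is this same change. No step beyond the scatter is therefore expected in this assay, and no direction is favoured (expected step no change at the digits printed from compound 3 to compound 4 (within the scatter)). The estimate for compound 4 is expected at 24000 nM (range 12000 nM to 45000 nM).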

Compound 4, half-maximal effective concentration: 36000 nM
Compound 4: the middle estimate sits 1.5-fold (0.18 log units) below what was measured, within the range that was stated.
By their numbers in this assay, from the lowest: compounds 1, 3, 2 and 4 (each within the scatter of the next).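

Across the ester chain of the series, 2-hydroxyethyl in place of hydrogen on this oxygen on a saturated carbon is tolerated in this assay without a step beyond the scatter (a 1.5-fold higher number from compound 3 to compound 4 (0.18 log units; within the scatter)). The larger 2-hydroxyethoxy group likewise stays within the scatter of the two plain chains (a 1.4-fold higher number from compound 2 to compound 4 (0.16 log units; within the scatter); a 1.6-fold higher number from compound 1 to compound 4 (0.19 log units; within the scatter)). No supporting measurement bears on this result.

Still open, as far as these compounds go, is whether an amine or a carboxylic acid on this oxygen, or a longer chain, would give a step beyond the scatter in this assay.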